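The source may hold more compounds than are shown below. What is called first, only, known or untested is meant among the compounds shown, and "the series" means these compounds.

Working notes on a small set of esters sharing one core. Compound 1 `CC1=C(C(=O)OC(C(F)(F)F)C(F)(F)F)C(c2ccoc2)NC(=O)N1`, compound 2 `CC1=C(C(=O)OC(C)C(F)(F)F)C(c2ccco2)NC(=O)N1` and compound 3 `CC1=C(C(=O)OCC(F)(F)F)C(c2ccco2)NC(=O)N1` have been run in an assay on cells for displacement of a labelled ligand from adenosine receptor A1 (Homo sapiens), read by radioligand binding, with a stated time of 60 min, tested at 1 uM; on this read-out lower numbers stand for less inhibition and higher numbers for more inhibition at the one concentration tested (going by the name of the read-out). In this assay compound 3 gives 10%. Compound 1 gives 7%, a number a few points lower than that of compound 3 and within the usual scatter of it, so the two cannot be ordered. Compound 2 gives 1%; 1% (2 entries), two entries rather than one number, both low. On the numbers shown compound 3 therefore stands at the higher of the two single numbers, with compound 1 within reach and compound 2 low on both entries; no step between these measured compounds is established beyond the scatter.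

The next compound, compound 4 `CC1=C(C(=O)OC(C(F)(F)F)C(F)(F)F)C(c2ccco2)NC(=O)N1`, is not yet measured in this assay. It differs from compound 3 in one place: trifluoromethyl in place of hydrogen on a saturated chain carbon bound to an oxygen next to a carbonyl group and a saturated chain carbon. Compound 1 already carries the same ester group as compound 4 and sits within the scatter of compound 3 on this read-out, so no step beyond the scatter is expected here; the step from compound 3 to compound 4 is estimated at a number 2 percentage points lower from compound 3 to compound 4 (within the scatter). For compound 4 the expected value in this assay is 8%, with a range from -5% to 22%, resting on compound 3 at 10% and compound 1 at 7%.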

Compound 4, a percentage reported as inhibition, at one concentration (the size of the read-out at that concentration, not a potency): 6%
Beside the measured number, compound 4's estimate is 2 percentage points above it; measured number inside the range.
By their numbers in this assay, from the lowest: compounds 4, 1 and 3 (each within the scatter of the next).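

In this assay, the step from hydrogen to trifluoromethyl on a saturated chain carbon bound to an oxygen next to a carbonyl group and a saturated chain carbon is a number 4 percentage points lower from compound 3 to compound 4 (within the scatter), so with furan-2-yl held constant, this change shows no step beyond the scatter. With the ester held constant, furan-2-yl in place of furan-3-yl on a saturated ring carbon gives a number 1 percentage points lower from compound 1 to compound 4 (within the scatter), so this pair likewise shows no separable difference between the two furan attachments on this read-out. Nothing measured in these notes bears on why these steps are small.

On these data alone, whether a longer chain or an amine in place of trifluoromethyl on that saturated chain carbon would move the number beyond the scatter remains open. Also open, as far as these compounds go, is whether a phenyl ring or a carboxylic acid in place of furan-2-yl on the saturated ring carbon would do so, since the two changes read here leave the series at low inhibition at the one concentration tested.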